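The source may report more compounds than this note shows. Statements on the series, on what has been measured and on what is new or still open speak of the compounds shown alone.

Series notes. Within the data shown here, compound 1 `COc1ccc(CNC(=O)/C(C#N)=C/c2ccco2)cc1` is the only member with a numbered read-out: in a functional assay on A-431 cells (Homo sapiens) for inhibition, read by MTT assay, with a stated time of 72 h (on this read-out higher numbers stand for weaker inhibition of growth and lower numbers for stronger inhibition of growth), compound 1 gives 16000 nM. Compound 2 `N#C/C(=C\c1ccco1)C(=O)NCc1ccc(Cl)c(Cl)c1` reaches only a limit in this assay, where compound 2 gives > 50000 nM. That limit is the one recorded as the limit of > 50000 nM in this assay, at which 1 of the 2 values shown sits, so compound 1 stands as the single numbered value among the two results shown. Compound 3 `COc1ccc(CNC(=O)/C(C#N)=C/c2ccc(Cl)o2)cc1` is not yet measured. It differs from compound 1 by chloro in place of hydrogen on an aromatic carbon, the same difference one bond further out reading furan-2-yl to 5-chlorofuran-2-yl. Among the measured compounds shown here, no step between measured compounds is available to set a size for such a change, so the expectation rests on compound 1 alone. In this assay a step of a 1.3-fold lower number from compound 1 to compound 3 (0.12 log units; within the scatter) is expected, not beyond the usual scatter. Compound 3 is accordingly estimated at 12000 nM, within 4000 nM to 40000 nM.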

Compound 3, concentration for 50% growth inhibition: 9000 nM
Estimate against measurement, compound 3: 1.3-fold (0.12 log units) above, and the stated range covers the measured number.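

In this assay, the change from furan-2-yl to 5-chlorofuran-2-yl gives a 1.8-fold lower number from compound 1 to compound 3 (0.25 log units; within the scatter) and so cannot be told apart from no effect on this read-out. Among these compounds, this is the first one-place step, and it shows that the aromatic carbon next to the ring oxygen can carry chloro in place of hydrogen without a shift beyond the scatter. No measurement shown bears on a reason for the size of this step.

Going by these compounds, whether this carbon also accepts an amine, a carboxylic acid or a longer chain in place of chloro remains open, so the reach of the position is defined by a single substituent. Also open, on these data alone, is whether the same step holds when the nitrile of the shared core is replaced by a carboxylic acid.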